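Triazole benzyl change toward the dimethoxy pattern

The compounds below may be only part of what the source reports. "The series", "measured", "known", "first", "only" and "open" are said of these compounds alone.

Compound 3 `COc1ccc(Cn2cc(CNC(=O)c3cn(-c4ccccc4)nc3-c3ccc(OC)cc3)nn2)cc1` stands second highest of the three numbers in a functional assay on MIA PaCa-2 cells (Homo sapiens) for antiproliferative activity, read by sulforhodamine B assay, with a stated time of 48 h (on this read-out lower numbers stand for stronger inhibition of growth and higher numbers for weaker inhibition of growth), where compound 3 gives 2500 nM. Going by the values given here, its nearest neighbour is compound 2 `COc1ccc(-c2nn(-c3ccccc3)cc2C(=O)NCc2cn(Cc3ccc(Cl)cc3)nn2)cc1`, which gives 26300 nM; the only measured step is an 11-fold lower number from compound 2 to compound 3 (1.02 log units; beyond the scatter), a methoxy-for-chloro change at a different site. Compound 1 `COc1cc(Cn2cc(CNC(=O)c3cn(-c4ccccc4)nc3-c3ccccc3)nn2)cc(OC)c1` gives 190 nM. Compound 4 `COc1ccc(-c2nn(-c3ccccc3)cc2C(=O)NCc2cn(Cc3cc(OC)cc(OC)c3)nn2)cc1` differs from compound 3 by 3,5-dimethoxyphenyl in place of 4-methoxyphenyl on a saturated chain carbon bound to an aromatic nitrogen. Among the compounds with values here, no measured step covers this change: compound 1 also carries the 3,5-dimethoxybenzyl, but differs from compound 3 at the second aryl as well, so its value only suggests that the dimethoxy pattern is compatible with a low number. A moderate downward step is therefore expected, a 3.6-fold lower number from compound 3 to compound 4 (0.55 log units; beyond the scatter). For compound 4 a value of 700 nM is estimated, within 150 nM to 3000 nM.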

Compound 4, concentration for 50% growth inhibition: 5800 nM
The estimate for compound 4 lay 8.3-fold (0.92 log units) below the measured number, outside the stated range (above it).
By their numbers in this assay, from the lowest: compound 1; then compound 3; then compound 4; then compound 2.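

In this assay, moving from 4-methoxybenzyl to 3,5-dimethoxybenzyl on the triazole side does not lower the number: the change gives a 2.3-fold higher number from compound 3 to compound 4 (0.37 log units; beyond the scatter). Against the 4-chlorophenyl group, the same 3,5-dimethoxyphenyl gives a 4.5-fold lower number from compound 2 to compound 4 (0.66 log units; beyond the scatter). With 3,5-dimethoxybenzyl held constant, adding a methoxy group at an aromatic carbon gives a 31-fold higher number from compound 1 to compound 4 (1.48 log units; beyond the scatter), so the dimethoxy pattern alone does not secure a low number. No measurement here gives a reason for these steps. Still open, from the compounds shown here alone, is how an amine at that aromatic carbon would compare with hydrogen and methoxy.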